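Hydroxymethyl in place of ester on the shared core

A few compounds are considered here, and "the series" means these few. Any claim that something is new, unique, unknown or untested is made for them only; others in the source may bear on it.

The series rests on two measured compounds. Compound 1 `CC(C)[C@H]1Cc2n[nH]cc2[C@@H](C(C)C)N1S(=O)(=O)c1ccc(C(F)(F)F)cc1` gives 10% in an ADME assay on microsomes from liver (Homo sapiens) for metabolic stability, using NADPH, with a stated time of 30 min, in the presence of a further agent that is not named here; a lower number here means that less of the compound is left, a higher number that more of the compound is left. Compound 2 `CCOC(=O)C1c2c[nH]nc2CCN1S(=O)(=O)c1ccc(Cl)cc1` gives 1% in this assay, the lowest of the two numbers, and its nearest neighbour is compound 1, whose value lies within the scatter of it. Compound 3 `O=S(=O)(c1ccc(Cl)cc1)N1CCc2n[nH]cc2C1CO` has not yet been measured; it differs from compound 2 in a single place: hydroxymethyl in place of ethoxycarbonyl on a saturated ring carbon. Among the compounds with values here, no step between measured compounds is available, so the size of this change has no direct precedent here. The expectation is a modest rise in this assay, probably beyond the scatter but not large, given that compound 2 starts at 1%. The step of a number 14 percentage points higher from compound 2 to compound 3 (beyond the scatter) is therefore expected to be upward. Compound 3 is estimated to give 15%, with a range of 3% to 40%.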

Compound 3, percent of the compound remaining: 84%
For compound 3 the middle estimate is 69 percentage points below the measured one; measured number above the stated range.
By their numbers in this assay, from the lowest: compounds 2 and 1 (each within the scatter of the next); then compound 3.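

In this assay, within the data shown here, hydroxymethyl in place of ethoxycarbonyl on this saturated ring carbon gives a number 83 percentage points higher from compound 2 to compound 3 (beyond the scatter), the first step between compounds that differ in one place. It shows that the low number of compound 2 is not fixed by the rest of the molecule, which compound 3 keeps unchanged: the exchange at this one carbon is enough to lift the read-out. Nothing measured here accounts for the size of this step.

The compounds shown leave open whether the free hydroxyl or the loss of the ester is what counts, which a methoxymethyl group, a carboxylic acid or a primary amide on the same carbon could separate. They also leave open whether the same exchange would carry over to a core bearing other groups, such as the isopropyl groups of compound 1.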